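Compound 1 and a methyl in place of hydrogen

The source may hold more compounds than are shown below. What is called first, only, known or untested is meant among the compounds shown, and "the series" means these compounds.

- compound 1 `COc1cc(C(=O)c2ccc(OC)c(O)c2OC)cc(OC)c1O` gives 4760 nM
- compound 2 `COc1cc(C(=O)c2ccc3c(c2)oc(=O)n3S(C)(=O)=O)cc(OC)c1OC` gives 4580 nM

In a functional assay on EKVX cells (Homo sapiens) for cytotoxicity, read by sulforhodamine B assay, with a stated time of 48 h (on this read-out lower numbers stand for stronger inhibition of growth and higher numbers for weaker inhibition of growth), compound 1 stands level with compound 2, since their two numbers lie within the usual scatter of each other. Compound 3 `COc1ccc(C(=O)c2cc(OC)c(OC)c(OC)c2)c(OC)c1O` differs from compound 1 in one place: methyl in place of hydrogen on an oxygen on an aromatic ring (methyl in place of hydrogen on an oxygen on an aromatic ring, or hydroxy to methoxy). Among the compounds with values here, no measured pair shows this change, so any forecast is uncertain. A clear move towards a lower number is expected, though a result within the scatter remains possible. The estimated step of a 9.5-fold lower number from compound 1 to compound 3 (0.98 log units; beyond the scatter) points towards stronger growth inhibition. Compound 3 is estimated at 500 nM (expected range 30 nM to 5000 nM).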

Compound 3, concentration for 50% growth inhibition: 611 nM
The estimate for compound 3 lay 1.2-fold (0.09 log units) below the measured number; the measured number falls inside the stated range.
By their numbers in this assay, from the lowest: compound 3; then compounds 2 and 1 (each within the scatter of the next).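

Putting a methyl in place of hydrogen on this oxygen gives a 7.8-fold lower number from compound 1 to compound 3 (0.89 log units; beyond the scatter) in this assay, so this single hydroxy to methoxy change clearly alters growth inhibition on these cells. Within the data shown here, it is the first step that lies beyond the scatter, and it shows that a free hydroxy at this position is not needed for this level of growth inhibition. Nothing available explains the size of this step. Still open, from the compounds shown here alone, is how an ethyl or a longer chain on this oxygen, or an amine in place of the hydroxy, would read here.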